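Chloro on the Far Ring: What Three Limits Allow

The compounds below may be only part of what the source reports. "The series", "measured", "known", "first", "only" and "open" are said of these compounds alone.

Compound 1, `CC1(C)Cc2c(ccc(C(=O)/C=C/c3ccc(Cl)cc3Cl)c2OCc2ccccc2)O1`, in a functional assay on HT-29 cells (Homo sapiens) for antiproliferative activity, read by MTT assay, with a stated time of 48 h (on this read-out higher numbers stand for weaker inhibition and lower numbers for stronger inhibition), gives > 100000 nM.
Compound 2, `CC1(C)Cc2c(OCc3ccccc3)ccc(C(=O)/C=C/c3cn(-c4ccccc4)nc3-c3ccc([N+](=O)[O-])cc3)c2O1`, in this assay gives > 100000 nM.
Compound 3, `CC1(C)Cc2c(ccc(C(=O)/C=C/c3ccccc3)c2OCc2ccccc2)O1`, in this assay gives > 100000 nM.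

Each of these three values is a limit of the assay and not a number. Compound 3 therefore stands at the limit, and so do compound 1 and compound 2 (the limit of > 100000 nM in this assay, at which 3 of the 3 values shown sit). Among the measured compounds shown here, the one measured step that alters a single place, a step that the two limits leave unreadable from compound 1 to compound 3, is unreadable in size, since both of its ends are limits.

Compound 4, `CC1(C)Cc2c(ccc(C(=O)/C=C/c3ccc(Cl)cc3)c2OCc2ccccc2)O1`, differs from compound 3 by chloro in place of hydrogen on an aromatic carbon. For the measured compounds named here, no measured step bears readably on this change, so no step beyond the scatter can be expected in this assay in either direction.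

Compound 4 is expected to sit at 150000 nM, within 30000 nM to 600000 nM. The expected step is a step that the limit leaves unreadable from compound 3 to compound 4, most likely reported again only as a limit.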

Compound 4, half-maximal inhibitory concentration: > 100000 nM
Compound 4 was reported as a limit; the forecaster's own chance of this, stated with the estimate: 85%; the middle value lies beyond the limit too.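

In this assay compound 4 gives > 100000 nM, again a limit and not a number. Its steps to compound 1 and compound 3 therefore cannot be read. Whether chloro in place of hydrogen changes activity stays open, since every compound shown stands at one limit: the limit of > 100000 nM in this assay, at which 4 of the 4 values shown sit.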